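The source may report more compounds than this note shows. Statements on the series, on what has been measured and on what is new or still open speak of the compounds shown alone.

Compound 1 `CC(=O)c1ccc2c(c1)C(n1ccccc1=O)=CC(C)(C)O2` and compound 2 `Cc1ccc(C)n1-c1ccc2c(c1)C(n1ccccc1=O)=CC(C)(C)O2` share one core and differ only in the group on the aromatic carbon of the six-membered carbon ring. In a functional assay (aorta) with Rattus norvegicus as the target (a higher number here means a more potent compound, by a factor of ten per unit of this negative logarithm, a lower number a less potent compound), compound 1 gives 7.37, and compound 2 gives 7.27. The step of a number 0.10 log units lower from compound 1 to compound 2 (within the scatter) is within the scatter, so the two numbers cannot be ordered, and compound 2 stands as one of two values that are indistinguishable from each other.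

Compound 3 `CC(=O)Oc1ccc2c(c1)C(n1ccccc1=O)=CC(C)(C)O2` has not yet been measured in this assay. It differs from compound 2 in one place: acetoxy in place of 2,5-dimethyl-1H-pyrrol-1-yl on an aromatic carbon. Among the measured compounds shown here, the only measured step that bears on this change is the one at the same aromatic carbon, from compound 1 to compound 2, and that step, a number 0.10 log units lower from compound 1 to compound 2 (within the scatter), was within the scatter; it showed that a change of the group at this position left the number essentially unchanged. On this basis the expected step of a number 0.03 log units higher from compound 2 to compound 3 (within the scatter) is none beyond the scatter. For compound 3 the estimate in this assay is 7.3, with a range from 6.7 to 7.9.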

Compound 3, logarithm of the reciprocal of the active concentration, log(1/C): 5.6
Compound 3: the middle estimate sits 1.70 log units above what was measured; measured number outside the range, below it.
By their numbers in this assay, from the lowest: compound 3; then compounds 2 and 1 (each within the scatter of the next).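

The aromatic carbon does not accept every group equally in this assay: acetoxy in place of 2,5-dimethyl-1H-pyrrol-1-yl gives a number 1.67 log units lower from compound 2 to compound 3 (beyond the scatter), and acetoxy in place of acetyl gives a number 1.77 log units lower from compound 1 to compound 3 (beyond the scatter), both large and beyond the scatter. The earlier agreement between compound 1 and compound 2 therefore did not mean that the number is insensitive to this position, and the acetoxy group of compound 3 separates from both, although it is an acetyl group joined to the aromatic carbon through oxygen. Nothing available here accounts for the difference made by acetoxy at this carbon.

The compounds shown leave open whether the lower number goes with the oxygen attached to the aromatic carbon or with the whole acetoxy group, a question that a hydroxyl, a methoxy or an acetamido group at the same carbon would help to settle. They also leave open how an amine or a carboxylic acid at this carbon would compare with acetyl, 2,5-dimethyl-1H-pyrrol-1-yl and acetoxy on the same shared core.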